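The compounds below may be only part of what the source reports. "The series", "measured", "known", "first", "only" and "open" are said of these compounds alone.

Compounds measured:
compound 1 `COc1cc(-c2cccn(Cc3ccc(CCC(=O)O)cc3)c2=O)ccc1NC(=O)Nc1ccccc1C`: "not determined" (no result reported)
compound 2 `Cc1ccccc1NC(=O)Nc1ccc(-c2cccn(Cc3ccc(CCC(=O)O)cc3)c2=O)cc1`: "not determined" (no result reported)
compound 3 `Cc1ccccc1NC(=O)Nc1ccc(-c2cccn(Cc3ccc([C@H](C)CC(=O)O)cc3)c2=O)cc1`: 16 mL/min/kg

Going by the values given here, of the three compounds that share this core, only one carries a number in an in vivo ADME assay on the whole organism for pharmacokinetics, with Rattus norvegicus as the target; on this read-out lower numbers stand for slow clearance and higher numbers for fast clearance. For compound 1 the entry in this assay reads "not determined" (no result reported), and for compound 2 it likewise reads "not determined" (no result reported). Compound 3 therefore stands alone on the numbers shown: in this assay compound 3 gives 16 mL/min/kg, and there is nothing in the series to set beside it, so no step between measured compounds can be drawn.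

Compound 4 `COc1cc(-c2cccn(Cc3ccc([C@H](C)CC(=O)O)cc3)c2=O)ccc1NC(=O)Nc1ccccc1C` is not yet measured. It differs from compound 3 in one place: methoxy in place of hydrogen on an aromatic carbon, a methoxy in place of hydrogen on an aromatic carbon. Among the compounds with values here, with no measured step of this kind available, nothing in the data argues for a shift beyond the usual scatter, in either direction. Compound 4 is thus expected to sit close to compound 3, an estimated step of a 1.1-fold higher number from compound 3 to compound 4 (0.05 log units; within the scatter). The estimate for compound 4 in this assay is 18 mL/min/kg, with a range from 8 mL/min/kg to 40 mL/min/kg.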

Compound 4, clearance: 9 mL/min/kg
Compound 4: middle estimate off by 2.0-fold (0.30 log units), on the high side, and the stated range covers the measured number.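

Compound 4 gives the series its first step between measured compounds. In this assay, methoxy in place of hydrogen on the aromatic carbon ortho to a ((2-methylphenyl)carbamoyl)amino group gives a 1.8-fold lower number from compound 3 to compound 4 (0.25 log units; within the scatter), so on this read-out the two compounds cannot be told apart. The same change separates compound 2 from compound 1, but that step cannot be read, as neither compound has a number. The data shown offer no measured explanation for the size of this step.

From the compounds shown here alone, it remains open whether a fluorine, a chlorine, an ethoxy or a hydroxyl at this position would also stay within the scatter of compound 3. Also open, going by these compounds, is whether methoxy would behave the same way alongside a shorter chain or an amide in place of the carboxylic acid.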